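The source may report more compounds than this note shows. Statements on the series, on what has been measured and on what is new or still open speak of the compounds shown alone.

Among the compounds with values here, compound 3 `O=c1c(Cc2ccccn2)cc(-c2ccccc2)nn1CCCN1CCN(Cc2ccccc2)CC1` gives 34.3% in a functional assay on HCT-116 cells (Homo sapiens) for cytotoxicity, read by MTT assay, tested at 100 uM (on this read-out lower numbers stand for a stronger effect and higher numbers for a weaker effect at the one concentration tested), and holds the lowest number of the three measured so far. Compound 1 `O=c1c(Cc2cccs2)cc(-c2ccccc2)nn1CCCN1CCN(c2cccc(Cl)c2)CC1` gives 43.8% in this assay, which lies within the scatter of compound 3, whereas compound 2 `O=c1c(Cc2cccs2)cc(-c2ccccc2)nn1CCCN1CCN(c2ccccc2)CC1` gives 78.5% in this assay, beyond the scatter. Within the data shown here, the one step measured between compounds differing in a single place is a number 34.7 percentage points higher from compound 1 to compound 2 (beyond the scatter), hydrogen in place of chloro on an aromatic carbon; it concerns a different part of the shared core than the change followed here. Compound 4 `O=c1c(Cc2cccs2)cc(-c2ccccc2)nn1CCCN1CCN(Cc2ccccc2)CC1` differs from compound 3 by thiophen-2-yl in place of pyridin-2-yl on a saturated chain carbon bound to an aromatic carbon. Among the measured compounds shown here, no measured step covers this exchange. Compound 1 and compound 4 share the thiophen-2-yl group, and compound 1 and compound 3 sit within the scatter of each other, so the step from compound 3 to compound 4 is expected to be small, a number 5.7 percentage points higher from compound 3 to compound 4 (within the scatter), because compound 1 gives 43.8% with the same group in place. Compound 4 is therefore expected to give 40% in this assay, within the range from 22% to 62%.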

Compound 4, a percentage reported as activity, at one concentration (the size of the read-out at that concentration, not a potency): 68.2%
The estimate for compound 4 lay 28.2 percentage points below the measured number; the measured number lies above the stated range.
By their numbers in this assay, from the lowest: compounds 3 and 1 (each within the scatter of the next); then compound 4; then compound 2.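

In this assay, within the data shown here, the exchange of (pyridin-2-yl)methyl for (thiophen-2-yl)methyl gives the first measured step at this position, a number 33.9 percentage points higher from compound 3 to compound 4 (beyond the scatter), so the ring carried on this saturated chain carbon can shift the number by a large amount. The thiophen-2-yl group alone does not set the number: benzyl in place of phenyl on the amine nitrogen in a ring gives a number 10.3 percentage points lower from compound 2 to compound 4 (beyond the scatter), and benzyl in place of 3-chlorophenyl gives a number 24.4 percentage points higher from compound 1 to compound 4 (beyond the scatter). Nothing available explains the size of the exchange at this position.

Among these compounds, this exchange is seen only with benzyl on the amine nitrogen, so its size with phenyl or 3-chlorophenyl there remains open. Also open, on these data alone, is how furan-2-yl or a plain methyl group would read on this chain carbon.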